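The source may report more compounds than this note shows. Statements on the series, on what has been measured and on what is new or still open speak of the compounds shown alone.

In an ADME assay on cells (Astrocyte, Rattus norvegicus, strain Wistar) for inhibition, read by sulforhodamine B assay, with a stated time of 72 h (on this read-out higher numbers stand for lower toxicity in this test and lower numbers for higher toxicity in this test), compound 3 `O=C(/C=C/c1ccc([N+](=O)[O-])o1)c1ccc(-n2ccnc2)cc1` gives 45300 nM. Compound 1 `CCC(=O)Oc1cccc2ccc(/C=C/c3ccccc3[N+](=O)[O-])nc12` gives 55200 nM and compound 2 `CSc1ccc(C(=O)/C=C/c2ccc([N+](=O)[O-])o2)cc1` gives 28400 nM; the number for compound 3 lies between these two, and both gaps to it are within the usual scatter. Compound 4 `O=C(/C=C/c1ccc([N+](=O)[O-])o1)c1ccc(N2CCNCC2)cc1` differs from compound 3 by piperazin-1-yl in place of 1H-imidazol-1-yl on an aromatic carbon. Within the data shown here, the only measured step that bears on this change, an exchange of the group on the same aromatic carbon in this assay, is a 1.6-fold higher number from compound 2 to compound 3 (0.20 log units; within the scatter), which stayed within the scatter. On that basis compound 4 is expected to show a 1.0-fold lower number from compound 3 to compound 4 (0.00 log units; within the scatter), that is, no step beyond the scatter. Compound 4 is therefore estimated at 45000 nM, with a range from 20000 nM to 100000 nM.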

Compound 4, half-maximal cytotoxic concentration: 44300 nM
Estimate against measurement, compound 4: 1.0-fold (0.01 log units) above, within the range that was stated.
By their numbers in this assay, from the lowest: compounds 2, 4, 3 and 1 (each within the scatter of the next).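

In this assay, the aromatic carbon para to a large group has now carried three groups without a step beyond the scatter: piperazin-1-yl in place of 1H-imidazol-1-yl gives a 1.0-fold lower number from compound 3 to compound 4 (0.01 log units; within the scatter), and piperazin-1-yl in place of methylsulfanyl gives a 1.6-fold higher number from compound 2 to compound 4 (0.19 log units; within the scatter). Here, exchanging a five-membered aromatic ring for a six-membered non-aromatic ring with a hydrogen-bond donor leaves the number within the scatter. Nothing available explains this result. On these data alone, whether a carboxylic acid or an open-chain amine at this place would also stay within the scatter remains open.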